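Carbamate chain variation and plasma free fraction

A few compounds are considered here, and "the series" means these few. Any claim that something is new, unique, unknown or untested is made for them only; others in the source may bear on it.

Measured compounds:
compound 1 `CCCCN(C)C(=O)OCc1c(-c2ccc(O[C@H]3CCC[C@H](C(=O)O)C3)c(C)n2)nnn1C`: 0.063
compound 2 `Cc1cc(-c2nnn(C)c2COC(=O)N(C)CCC(C)C)ccc1O[C@H]1CCC[C@H](C(=O)O)C1`: 0.012
compound 3 `Cc1noc(-c2ccc(O[C@H]3CCC[C@H](C(=O)O)C3)cc2)c1COC(=O)N(C)C1CCCC1`: 0.002

All three values come from an ADME assay on the whole organism (plasma, Rattus norvegicus, strain Sprague-Dawley) for protein binding, read by LC-MS, with a stated time of 24 h; on this read-out lower numbers stand for a smaller free fraction and higher numbers for a larger free fraction. Compound 1 holds the highest number of the three; compound 2 stands nearest and compound 3 furthest, with both gaps beyond the usual scatter. Within the data shown here, no pair among the measured compounds differs in a single place, so no measured step can be isolated.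

Compound 4 `Cc1nc(-c2nnn(C)c2COC(=O)N(C)CC2CCC2)ccc1O[C@H]1CCC[C@H](C(=O)O)C1` is not yet measured. It differs from compound 1 by cyclobutyl in place of propyl on a saturated chain carbon bound to an amide-type nitrogen. The expected step of a 1.4-fold lower number from compound 1 to compound 4 (0.15 log units; within the scatter) is small and downward, most likely within the scatter. For compound 4 the estimated unbound fraction is 0.045, with a range from 0.02 to 0.1.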

Compound 4, unbound fraction: 0.053
Compound 4: the middle estimate sits 1.2-fold (0.07 log units) below what was measured; measured number inside the range.
By their numbers in this assay, from the lowest: compound 3; then compound 2; then compounds 4 and 1 (each within the scatter of the next).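

In this assay, among these compounds, the one step that can be read, a 1.2-fold lower number from compound 1 to compound 4 (0.08 log units; within the scatter), lies within the scatter, so cyclobutyl in place of propyl on a saturated chain carbon bound to an amide-type nitrogen does not separate compound 4 from compound 1. At this position a carbon ring is therefore tolerated with no measurable shift in free fraction. No supporting evidence bears on this result.

Steps to compound 2 and compound 3 cannot be read, as each differs from compound 1 in more than one place. Going by these compounds, whether a hydroxyl or a tertiary amine on this chain would move the free fraction remains open.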